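Hydroxy for amino at the carbonyl carbon

A few compounds are considered here, and "the series" means these few. Any claim that something is new, unique, unknown or untested is made for them only; others in the source may bear on it.

Compound 2 `NC(=O)/C=C/c1ccncc1-c1ccc2ccccc2c1` is known only as a limit in a functional assay on A549 cells (Homo sapiens) for inhibition, read by sulforhodamine B assay, with a stated time of 72 h; a higher number here means a weaker inhibitor of growth, a lower number a stronger inhibitor of growth: compound 2 gives > 10000 nM. Compound 1 `O=C(O)/C=C/c1ccncc1-c1ccc2cc[nH]c2c1` also reaches only a limit, giving > 10000 nM in this assay. Compound 3 `CNC(=O)/C=C/c1ccncc1-c1ccc2[nH]ccc2c1` likewise stands at a limit, with > 10000 nM in this assay. Within the data shown here, compound 2 therefore stands where every value so far stands, at the limit of > 10000 nM in this assay, at which 3 of the 3 values shown sit, and no step between measured compounds can be sized.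

Compound 4 `O=C(O)/C=C/c1ccncc1-c1ccc2ccccc2c1` is not yet measured. Its change from compound 2 is hydroxy in place of amino on a carbonyl carbon. Compound 1 carries the same carboxy group and sits at > 10000 nM in this assay, so no step beyond the scatter is expected. The expected step in this assay is a step that the limit leaves unreadable from compound 2 to compound 4. Compound 4 is estimated at 20000 nM, between 8000 nM and 60000 nM, most probably again a limit.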

Compound 4, concentration for 50% growth inhibition: > 10000 nM
Compound 4 gave a limit, no number; the forecaster's own chance of this, stated with the estimate: 85%; the middle value does not contradict the limit.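

Compound 2 and compound 4 both stand at a limit, so no step between them can be read: the limit of > 10000 nM in this assay, at which 4 of the 4 values shown sit.

The compounds shown leave open which change, if any, would bring growth inhibition to a readable number.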